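This account rests on a few compounds, and the source may have more. Where it says the series, first, only, none or still open, it means among the compounds named here.

The account follows a small set of compounds built on a shared four-membered lactam core. Compound 1 `CCOC(=O)/C(=C/c1ccccc1)CN1C(=O)[C@@H](OC)[C@H]1c1ccc(F)cc1` was examined in a functional assay on MCF7 cells (Homo sapiens) for antiproliferative activity, read by MTT assay, with a stated time of 48 h (a higher number here means a weaker inhibitor, a lower number a stronger inhibitor), and gave 18800 nM. Compound 2 `COc1ccc(OC)c([C@@H]2[C@H](OC)C(=O)N2C/C(C#N)=C/c2ccccc2)c1` belongs to the same series, and in this assay compound 2 gives no result reported. Compound 3 `COC(=O)/C(=C/c1ccccc1)CN1C(=O)[C@@H](OC)[C@H]1c1cccc(F)c1`, in which the 3-fluorophenyl group occupies the saturated ring carbon, gave 13700 nM in this assay; set beside compound 1, its number differs by an amount that falls within the usual scatter of the method, so the two compounds cannot be told apart on these figures. Going by the values given here, no two measured compounds differ at a single point, so the data hold no single-change step against which a new change could be weighed.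

Compound 4 `COC(=O)/C(=C/c1ccccc1)CN1C(=O)[C@@H](OC)[C@H]1c1ccc(OC)cc1` is the next member. Relative to compound 3, its change is 4-methoxyphenyl in place of 3-fluorophenyl on a saturated ring carbon. Among the compounds with values here, with no measured step of this kind to draw on, the expectation is that the move from compound 3 to compound 4 in this assay is a 1.1-fold higher number from compound 3 to compound 4 (0.04 log units; within the scatter), a shift that is not expected to pass beyond the scatter in either direction. On that basis compound 4 is estimated to give 15000 nM in this assay, with a likely range from 5000 nM to 45000 nM.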

Compound 4, half-maximal inhibitory concentration: 11600 nM
For compound 4 the middle estimate is 1.3-fold (0.11 log units) above the measured one; the measured number falls inside the stated range.
By their numbers in this assay, from the lowest: compounds 4, 3 and 1 (each within the scatter of the next).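

Going by these compounds alone, replacing 3-fluorophenyl with 4-methoxyphenyl on the saturated ring carbon gives a 1.2-fold lower number from compound 3 to compound 4 (0.07 log units; within the scatter) in this assay, and this is the first single-change step. It shows that this position accepts an exchange of one substituted phenyl group for another, including a change in the substituent and where it stands on the phenyl ring, without a number that can be told apart from that of the starting compound. The entering group also carries a hydrogen-bond acceptor that the leaving group lacks, yet the step stays within the scatter, and no independent measurement is available to interpret this result.

It remains open whether any group at this ring carbon would shift the number beyond the scatter, since a phenyl ring bearing an amine or a carboxylic acid, or a longer chain in place of the phenyl ring, lies outside the compounds shown. Within the data shown here, the ester and the methoxy group on the shared core have no single-change step of their own, so their contribution to the numbers cannot be judged here.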